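Trading Chloro for Trifluoromethyl on an Aromatic Ring

The source may hold more compounds than are shown below. What is called first, only, known or untested is meant among the compounds shown, and "the series" means these compounds.

Of the compounds shown here, three sharing one core have been tested in a functional assay on HCT-116 cells (Homo sapiens) for cytotoxicity, read by MTT assay, with a stated time of 48 h; a higher number here means a weaker inhibitor, a lower number a stronger inhibitor. Compound 1 `CNC(=O)c1ccc(Sc2ccc(NC(=S)Nc3cc(C(F)(F)F)cc(C(F)(F)F)c3)cc2)nc1` gives 16600 nM, compound 2 `CNC(=O)c1ccc(Sc2ccc(NC(=S)Nc3cccc(C)c3)cc2)nc1` gives 52400 nM, and compound 3 `CNC(=O)c1ccc(Sc2cccc(NC(=S)Nc3ccc(F)c(Cl)c3)c2)nc1` gives 17300 nM. Compound 3 thus holds the second highest of the three numbers: its value and that of compound 1 lie within the scatter of each other, so no order between them can be read, while compound 2 sits beyond the scatter with the higher number and is the weaker inhibitor of the three.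

Compound 4 `CNC(=O)c1ccc(Sc2cccc(NC(=S)Nc3ccc(F)c(C(F)(F)F)c3)c2)nc1` has not been measured. It differs from compound 3 in one place: trifluoromethyl in place of chloro on an aromatic carbon. The trifluoromethyl enters on an aromatic carbon of a six-membered aromatic ring of carbon only, ortho to a fluoro group and meta to a large group. For the measured compounds named here, no measured pair shows exactly this change, so its effect is unknown here. Compound 1 also carries trifluoromethyl and gives 16600 nM, close to compound 3, which suggests such a group is tolerated. The step is expected to be small, at most a modest move toward a lower number and likely not beyond the scatter: a 1.4-fold lower number from compound 3 to compound 4 (0.16 log units; within the scatter). Compound 4 is therefore estimated at 12000 nM, within a range from 5000 nM to 30000 nM.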

Compound 4, half-maximal inhibitory concentration: 18200 nM
For compound 4 the middle estimate is 1.5-fold (0.18 log units) below the measured one, and the stated range covers the measured number.
By their numbers in this assay, from the lowest: compounds 1, 3 and 4 (each within the scatter of the next); then compound 2.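

In this assay, trading chloro for trifluoromethyl on this aromatic carbon, ortho to a fluoro group and meta to a large group, gives a 1.1-fold higher number from compound 3 to compound 4 (0.02 log units; within the scatter), so the read-out does not separate the two groups. For the compounds shown here, this is the only pair here that differs in one place, and it shows directly what the earlier comparisons could not: at this position, 1 heavy atom can be replaced by a group of 4 heavy atoms without a difference that can be read in this cell assay. Nothing available here explains why the two groups read alike.

Going by these compounds, what this position does with a different kind of group remains open, for example a methoxy, an amine or a carboxylic acid, or with plain hydrogen, which would show whether any group is needed there at all. Also open, on these data alone, is whether the same trade would read alike on the core of compound 1, where the thiourea-bearing ring is joined differently to the sulfur.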